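Halogen swap on the aryl piperazine of an inactive pair

The compounds below may be only part of what the source reports. "The series", "measured", "known", "first", "only" and "open" are said of these compounds alone.

Compound 1 `Fc1cc(Cl)ccc1N1CCN(Cc2ccn3c(CC4CC4)nnc3c2C(F)(F)F)CC1` in a functional assay on HEK293 cells for agonist activity at metabotropic glutamate receptor 6 (Homo sapiens), read by a luciferase reporter and cAMP accumulation (a higher number here means that more compound is needed for the effect, a lower number that less compound is needed), gives > 10000 nM, which is a limit of the assay rather than a number. Compound 2 `Fc1ccc(N2CCN(Cc3cc(C(F)(F)F)cn4c(CC5CC5)nnc34)CC2)c(F)c1` in this assay gives > 10000 nM, again a limit. Going by the values given here, both results sit at the limit of > 10000 nM in this assay, at which 2 of the 2 values shown sit, so compound 1 stands level with the one other measured compound and nothing can be ranked between them. Among the compounds with values here, no step between measured compounds that differ in one place is available, so no measured size of change in this assay exists to lean on.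

Compound 3 `Fc1ccc(N2CCN(Cc3ccn4c(CC5CC5)nnc4c3C(F)(F)F)CC2)c(Cl)c1` differs from compound 1 by 2-chloro-4-fluorophenyl in place of 4-chloro-2-fluorophenyl on an amine nitrogen in a ring: the same atoms joined differently, with 2-chloro-4-fluorophenyl entering for 4-chloro-2-fluorophenyl on the amine nitrogen in the six-membered non-aromatic ring with two nitrogens. Given that compound 1 and compound 2 both return only a limit, the step that the limit leaves unreadable from compound 1 to compound 3 is expected to be none beyond the scatter, and compound 3 is expected most likely to return a limit once more. Compound 3 is expected to give 15000 nM, within a range of 5000 nM to 50000 nM.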

Compound 3, half-maximal effective concentration: > 10000 nM
Compound 3: no number, only a limit; the forecaster's own chance of this, stated with the estimate: 80%; the middle value lies beyond the limit too.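

Compound 3 gives > 10000 nM in this assay, a limit of the assay and not a number. No step can be read between compound 1 and compound 3, as both return only a limit: the limit of > 10000 nM in this assay, at which 3 of the 3 values shown sit.

The compounds shown leave open which change to the shared core or the aryl group, if any, would give a measurable value in this assay.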